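Replacing pyrrolidin-1-yl with chloromethyl: compound 3 to compound 4

The source may report more compounds than this note shows. Statements on the series, on what has been measured and on what is new or still open speak of the compounds shown alone.

Measured so far in a functional assay on HepG2 cells (Homo sapiens) for cytotoxicity, read by MTT assay, with a stated time of 72 h; on this read-out lower numbers stand for stronger inhibition and higher numbers for weaker inhibition
- compound 1 `Cc1ccc(-c2nc3cc(NC(=O)CCN4CCCCC4)ccc3[nH]2)cc1` gives 11900 nM
- compound 2 `Cc1ccc(-c2nc3cc(NC(=O)CN4CCCCC4)ccc3[nH]2)cc1` gives > 50000 nM as a limit
- compound 3 `Cc1ccc(-c2nc3cc(NC(=O)CN4CCCC4)ccc3[nH]2)cc1` gives > 50000 nM as a limit

Compound 3 stands at the limit of > 50000 nM in this assay, at which 2 of the 3 values shown sit, and so has no numerical value. Compound 4 `Cc1ccc(-c2nc3cc(NC(=O)CCCl)ccc3[nH]2)cc1` has chloromethyl in place of pyrrolidin-1-yl on a saturated chain carbon bound to a carbonyl carbon. Among the compounds with values here, no measured step makes this exact change. The nearest are an at least 4.2-fold higher number from compound 1 to compound 3 (0.62 log units; beyond the scatter) and an at least 4.2-fold higher number from compound 1 to compound 2 (0.62 log units; beyond the scatter), both changes in this same place, while a step that the two limits leave unreadable from compound 2 to compound 3. On the strength of an at least 4.2-fold higher number from compound 1 to compound 3 (0.62 log units; beyond the scatter) as a step of that place, a modest move is expected, uncertain in size. The step expected in this assay is an at least 2.7-fold lower number from compound 3 to compound 4 (0.44 log units; beyond the scatter), towards a lower number. For compound 4 the estimated value is 18000 nM, with an expected range of 6000 nM to 50000 nM.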

Compound 4, half-maximal inhibitory concentration: > 50000 nM
Compound 4 gave a limit, no number; the forecaster's own chance of this, stated with the estimate: 30%; at least 2.7-fold (0.44 log units) between middle value and limit.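

In this assay compound 4 gives > 50000 nM, which is a limit and not a number. Exchanging piperidin-1-yl for chloro on the same chain gives an at least 4.2-fold higher number from compound 1 to compound 4 (0.62 log units; beyond the scatter), so this chain without the piperidin-1-yl does not keep a measured value. The steps from compound 2 and compound 3 to compound 4 cannot be read, and compound 1 alone holds a number: the limit of > 50000 nM in this assay, at which 3 of the 4 values shown sit.

From the compounds shown here alone, how far the limited compounds lie from that limit stays open. Also open, going by these compounds, is whether a longer chain ending in piperidin-1-yl, or a morpholine on the chain of compound 1, moves the value from 11900 nM.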